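Replacing the amine substituent of compound 3

The compounds below may be only part of what the source reports. "The series", "measured", "known", "first", "only" and "open" are said of these compounds alone.

Compound 1 `C=C(C)C(=O)NCCOc1ccc(Oc2c(-c3ccc(F)cc3)sc3cc(O)ccc23)cc1`: > 25000 nM, a limit
Compound 2 `C/C=C/C(=O)N1CC(Oc2ccc(Oc3c(-c4ccc(F)cc4)sc4cc(O)ccc34)cc2)C1`: 28000 nM
Compound 3 `CNC(=O)/C=C/CNCCOc1ccc(Oc2c(-c3ccc(F)cc3)sc3cc(O)ccc23)cc1`: 16100 nM

In a functional assay on MCF7 cells (Homo sapiens) for antiproliferative activity, read by CCK-8 assay, with a stated time of 48 h (on this read-out lower numbers stand for stronger inhibition and higher numbers for weaker inhibition), compound 3 lies within the scatter of compound 2, as a 1.7-fold lower number from compound 2 to compound 3 (0.24 log units; within the scatter) shows. Compound 4 `C/C=C/C(=O)NCCOc1ccc(Oc2c(-c3ccc(F)cc3)sc3cc(O)ccc23)cc1` carries (prop-1-en-1-yl)carbonyl in place of 3-(methylcarbamoyl)prop-2-en-1-yl on an amine nitrogen. For the measured compounds named here, two measured steps bear on this change. One is an at least 1.5-fold lower number from compound 1 to compound 3 (0.19 log units; that floor lies within the scatter), which replaces the same substituent with a different carbonyl group. The other is a 1.7-fold lower number from compound 2 to compound 3 (0.24 log units; within the scatter), which also changes the group on the oxygen. Neither goes beyond the scatter, so no clear shift is expected, only a slight tilt towards a higher number. The expected step is a 1.6-fold higher number from compound 3 to compound 4 (0.21 log units; within the scatter). Compound 4 is estimated at 26000 nM, within a range of 13000 nM to 50000 nM.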

Compound 4, half-maximal inhibitory concentration: 21700 nM
Compound 4: middle estimate off by 1.2-fold (0.08 log units), on the high side, and the stated range covers the measured number.
By their numbers in this assay, from the lowest: compounds 3, 4 and 2 (each within the scatter of the next).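

Setting (prop-1-en-1-yl)carbonyl on the amine nitrogen gives a 1.3-fold higher number from compound 3 to compound 4 (0.13 log units; within the scatter) in this assay, so this exchange on the nitrogen does not move the number beyond the scatter. With the same carbonyl group kept, 2-(((prop-1-en-1-yl)carbonyl)amino)ethyl on the oxygen gives a 1.3-fold lower number from compound 2 to compound 4 (0.11 log units; within the scatter) and again separates nothing. Prop-1-en-1-yl in place of 1-methylethenyl gives an at least 1.1-fold lower number from compound 1 to compound 4 (0.06 log units; that floor lies within the scatter) and yields only a floor, compound 1 being a limit: the limit of > 25000 nM in this assay, at which 1 of the 4 values shown sits.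

From the compounds shown here alone, whether any group on this nitrogen can lower the number beyond the scatter stays open. A carboxylic acid, a piperidine or a longer chain there could show it.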